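Extending methyl to ethyl on compound 3

The source may report more compounds than this note shows. Statements on the series, on what has been measured and on what is new or still open speak of the compounds shown alone.

Compound 1 `CCN1C(=O)C(O)(Cc2nnn[nH]2)c2ccccc21`: > 100000 nM, a limit of the assay, not a number
Compound 2 `CN1C(=O)C(O)(Cc2nnn[nH]2)c2cc(F)ccc21`: > 100000 nM, a limit of the assay, not a number
Compound 3 `CN1C(=O)C(O)(Cc2nnn[nH]2)c2cc(Cl)ccc21`: 76000 nM

For the measured compounds named here, in a functional assay on DU-145 cells (Homo sapiens) for antiproliferative activity, read by MTT assay, with a stated time of 48 h (on this read-out lower numbers stand for stronger inhibition and higher numbers for weaker inhibition), compound 3 gives 76000 nM, the only true number among the three. The other two readings sit at the limit of > 100000 nM in this assay, at which 2 of the 3 values shown sit.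

Compound 4 `CCN1C(=O)C(O)(Cc2nnn[nH]2)c2cc(Cl)ccc21` differs from compound 3 at one place, where methyl becomes ethyl: methyl in place of hydrogen on a saturated chain carbon bound to an amide-type nitrogen in a ring. Going by the values given here, the one measured step, an at least 1.3-fold lower number from compound 2 to compound 3 (0.11 log units; that floor lies within the scatter), concerns a different place and does not size this change. Compound 1 also carries the ethyl, but it has no chloro and its reading is only a limit.

The expectation therefore rests on compound 3 at 76000 nM, with no shift beyond the scatter foreseen. The expected change is a 1.1-fold lower number from compound 3 to compound 4 (0.04 log units; within the scatter). For compound 4 the estimated value is 70000 nM, with an expected range from 32000 nM to 130000 nM.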

Compound 4, half-maximal inhibitory concentration: 21500 nM
Estimate against measurement, compound 4: 3.3-fold (0.51 log units) above; measured number below the stated range.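

In this assay, this position responds to a small change: going from methyl to ethyl, with a single added carbon on the saturated chain carbon bound to an amide-type nitrogen in a ring, gives a 3.5-fold lower number from compound 3 to compound 4 (0.55 log units; beyond the scatter). With the ethyl in place, the aromatic carbon also matters, since chloro in place of hydrogen there gives an at least 4.6-fold lower number from compound 1 to compound 4 (0.66 log units; beyond the scatter). Compound 1 reads only as a limit, so that second step is a floor and not a full size: the limit of > 100000 nM in this assay, at which 2 of the 4 values shown sit.

The compounds shown leave open whether a longer chain such as propyl or butyl on that nitrogen would lower the number further or reverse the step. They also leave open whether the ethyl step would hold with bromo or with fluoro on the aromatic carbon instead of chloro.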